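The source may report more compounds than this note shows. Statements on the series, on what has been measured and on what is new or still open speak of the compounds shown alone.

In a functional assay on the whole organism for inhibition, with Rattus norvegicus as the target, at a dose of 30 mg/kg (on this read-out higher numbers stand for more inhibition at the one dose given (going by the name of the read-out) and lower numbers for less inhibition), compound 1, `c1ccc(-c2nc3cccnc3o2)cc1`, gives 55%. Compound 2, `O=[N+]([O-])c1ccccc1-c1nc2cccnc2o1`, is compound 1 with a single nitro group added to the same core, and in this assay compound 2 gives 57%. Among the compounds with values here, the only step measured so far, a number 2 percentage points higher from compound 1 to compound 2 (within the scatter), leaves the two numbers within the scatter of each other, so compound 2 stands alongside compound 1 with nothing to separate them.

Compound 3, `Brc1ccccc1-c1nc2cccnc2o1`, has not yet been measured. It differs from compound 2 as follows: bromo in place of nitro on an aromatic carbon. Within the data shown here, the one step that bears on this position is the step from compound 1 to compound 2, which put the nitro group there and moved the number only within the scatter. Among the measured compounds shown here, a second exchange at the same aromatic carbon, now to bromo, has no further measured precedent in this set. Compound 3 is therefore expected to show no step beyond the scatter, with a number 2 percentage points lower from compound 2 to compound 3 (within the scatter) as the estimated change. The estimate for compound 3 in this assay is 55%, ranging from 35% to 75%.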

Compound 3, a percentage reported as inhibition, in the whole organism at one dose (the size of the read-out at that dose, not a potency): 31%
The estimate for compound 3 lay 24 percentage points above the measured number; measured number below the stated range.
By their numbers in this assay, from the lowest: compound 3; then compounds 1 and 2 (each within the scatter of the next).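

In this assay the exchange of nitro for bromo on the aromatic carbon brought a number 26 percentage points lower from compound 2 to compound 3 (beyond the scatter) and bromo in place of hydrogen at that same carbon brought a number 24 percentage points lower from compound 1 to compound 3 (beyond the scatter) in turn. The position therefore does respond to what sits on it, which the comparison of hydrogen with nitro alone could not show, and the loss of inhibition at the one dose given goes with bromo specifically and not with the mere presence of a group there, as compound 2 with its nitro stays within the scatter of compound 1. Nothing in hand gives any information on what lies behind this drop.

As far as these compounds go, whether the fall is particular to bromo or is shared by other groups on this carbon, such as chloro, methoxy or an amine, remains open. Also open is whether bromo on another carbon of the six-membered aromatic ring would give a similar number, and how any of these compounds would compare at other doses.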